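A few compounds are considered here, and "the series" means these few. Any claim that something is new, unique, unknown or untested is made for them only; others in the source may bear on it.

Measured in a functional assay on HepG2 cells (Homo sapiens) for antiproliferative activity, read by MTT assay, with a stated time of 48 h; a higher number here means a weaker inhibitor, a lower number a stronger inhibitor:
Compound 1 `N#CC1=C(N)Oc2c(c3nc4ccccc4nc3c3ccccc23)C12C(=O)N(Cc1cnnn1-c1cccc(S(N)(=O)=O)c1)c1ccccc12` gives 21500 nM.
Compound 2 `Cc1ccc(-n2nncc2CN2C(=O)C3(C(C#N)=C(N)Oc4c3c3nc5ccccc5nc3c3ccccc43)c3ccccc32)c(C)c1` gives only a limit of this assay, > 50000 nM.
Compound 3 `N#CC1=C(N)Oc2c(N)cc3nc4ccccc4nc3c2C12C(=O)N(Cc1cnnn1-c1ccc(F)cc1)c1ccccc12` gives only a limit of this assay, > 50000 nM.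

Compound 3 thus stands at the limit, where (the limit of > 50000 nM in this assay, at which 2 of the 3 values shown sit). Compound 4 `Cc1ccc(Cl)cc1-n1nncc1CN1C(=O)C2(C(C#N)=C(N)Oc3c(N)cc4nc5ccccc5nc4c32)c2ccccc21` differs from it in one place: 5-chloro-2-methylphenyl in place of 4-fluorophenyl on an aromatic nitrogen. Among the measured compounds shown here, the one measured step at this same place, on the aromatic nitrogen, is an at least 2.3-fold higher number from compound 1 to compound 2 (0.36 log units; beyond the scatter), where a neutral aryl group replaced a polar one and the number rose; the swap here is likewise between two neutral aryl groups, starting from a compound already at the limit. Compound 4 is therefore expected to stay at or beyond the limit, with an estimated 70000 nM in a range from 25000 nM to 200000 nM, and the expected step is a step that the limit leaves unreadable from compound 3 to compound 4.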

Compound 4, half-maximal inhibitory concentration: 17300 nM
Compound 4: middle estimate off by 4.0-fold (0.61 log units), on the high side; measured number outside the range, below it.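

In this assay, the earlier step at this place showed only a loss, whereas this one shows that changing the aryl group on the aromatic nitrogen can also lift a compound off the limit: 5-chloro-2-methylphenyl in place of 4-fluorophenyl gives an at least 2.8-fold lower number from compound 3 to compound 4 (0.46 log units; beyond the scatter). The true size of this step remains unknown, because compound 3 has no exact number: the limit of > 50000 nM in this assay, at which 2 of the 4 values shown sit.

Whether the chlorine or the methyl accounts for the change stays open. So does the effect of a phenyl carrying an amine or a carboxylic acid at this place.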